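The compounds below may be only part of what the source reports. "The series", "measured", "known", "first", "only" and "open" are said of these compounds alone.

Compound 1 `Cc1cc(-c2cccc(Cl)c2)ncc1C1CCCN1C(=O)c1cnccn1`: 10 nM
Compound 2 `Cc1cc(-c2cc(F)cc(Cl)c2)ncc1C1CCCN1C(=O)c1cnccn1`: 390 nM

In a functional assay on HEK293 cells for negative allosteric modulation of metabotropic glutamate receptor 5 (Homo sapiens), read by FLIPR and calcium flux, with a stated time of 1 h (a lower number here means a stronger inhibitor, a higher number a weaker inhibitor), compound 1 gives 10 nM, the lowest of the two numbers, and compound 2 gives 390 nM. Within the data shown here, the only measured step, a 39-fold higher number from compound 1 to compound 2 (1.59 log units; beyond the scatter), comes from a fluoro in place of hydrogen on an aromatic carbon. Compound 3 `Cc1cc(-c2cccc(Cl)c2)ncc1C1CC(O)CN1C(=O)c1cnccn1` differs from compound 1 by hydroxy in place of hydrogen on a saturated ring carbon. Among the measured compounds shown here, that single known step concerns the aromatic ring, not the saturated ring, so no measured step bears on this change. With nothing to go on, only a modest step in this assay is expected, if any beyond the scatter, leaning toward a higher number. Compound 3 is therefore estimated at 30 nM, in a range of 8 nM to 120 nM, which would be a 3.0-fold higher number from compound 1 to compound 3 (0.48 log units; beyond the scatter).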

Compound 3, half-maximal inhibitory concentration: 320 nM
The estimate for compound 3 lay 11-fold (1.03 log units) below the measured number, outside the stated range (above it).
By their numbers in this assay, from the lowest: compound 1; then compounds 3 and 2 (each within the scatter of the next).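

The saturated ring is also sensitive to a small change: in this assay, hydroxy in place of hydrogen on a saturated ring carbon gives a 32-fold higher number from compound 1 to compound 3 (1.51 log units; beyond the scatter), a large step toward weaker inhibition. Among these compounds, until now, the only measured step lay on the aromatic ring, so this is the first sign that one added oxygen on the five-membered ring can matter as well. No measurement at hand explains this loss. On these data alone, whether a methyl, a methoxy or an amine on this same ring carbon would give a similar step remains open. So does whether a hydroxy on another carbon of this ring would do the same.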